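The compounds below may be only part of what the source reports. "The series", "measured", "known", "first", "only" and "open" are said of these compounds alone.

Working notes on the series

The shared core carries an aryl group that is varied across three measured compounds and one still to be measured. Compound 1 `COc1ccc(-c2cn3ccnc3c(-c3ccc4ncn(C5CCCCC5)c4c3)n2)cc1` bears a 4-methoxyphenyl. In a functional assay on MDA-MB-231 cells (Homo sapiens) for inhibition, read by sulforhodamine B assay, with a stated time of 48 h, tested at 10 uM (on this read-out higher numbers stand for more inhibition at the one concentration tested (going by the name of the read-out) and lower numbers for less inhibition), compound 1 gives 71.1%. Compound 2 `Fc1ccc(-c2cn3ccnc3c(-c3ccc4ncn(C5CCCCC5)c4c3)n2)cc1` differs from compound 1 by fluoro in place of methoxy on an aromatic carbon; in this assay compound 2 gives 15.8%, which is a number 55.3 percentage points lower from compound 1 to compound 2 (beyond the scatter). Compound 3 `COc1ccccc1-c1cn2ccnc2c(-c2ccc3ncn(C4CCCCC4)c3c2)n1` has the same atoms as compound 1 joined differently, the difference being (2-methoxyphenyl in place of 4-methoxyphenyl on an aromatic carbon). In this assay compound 3 gives 15.9%, a step of a number 55.2 percentage points lower from compound 1 to compound 3 (beyond the scatter), while the comparison of compound 2 and compound 3 is a number 0.1 percentage points higher from compound 2 to compound 3 (within the scatter).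

Compound 4 `Fc1ccccc1-c1cn2ccnc2c(-c2ccc3ncn(C4CCCCC4)c3c2)n1` is not yet measured. It differs from compound 3 by fluoro in place of methoxy on an aromatic carbon. Within the data shown here, this is the same kind of change as the one from compound 1 to compound 2, but the place is not identical: in compound 1 to compound 2 the fluoro enters para to a large group, whereas in compound 3 to compound 4 it enters ortho to a large group.

The earlier instance of this change was large, yet it started from the high value of compound 1. Compound 3 already sits near compound 2, so a further fall of similar size has little room. The expectation for compound 4 is a step of a number 3.9 percentage points lower from compound 3 to compound 4 (within the scatter) in this assay, within the scatter, because compound 3 gives only 15.9%. Compound 4 is therefore estimated at 12%, with a likely range from 0% to 35%.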

Compound 4, a percentage reported as inhibition, at one concentration (the size of the read-out at that concentration, not a potency): 21.3%
Beside the measured number, compound 4's estimate is 9.3 percentage points below it, within the range that was stated.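

Fluoro in place of methoxy does not carry from one core to the other in this assay, as the large fall seen when the change is made on the 4-methoxyphenyl compound does not recur on the 2-methoxyphenyl compound: the same change on two cores in this assay, a number 55.3 percentage points lower (beyond the scatter) from compound 1 to compound 2 and a number 5.4 percentage points higher (within the scatter) from compound 3 to compound 4, 60.7 percentage points apart, beyond the scatter of two such steps

The new step is a number 5.4 percentage points higher from compound 3 to compound 4 (within the scatter), the comparison of the two fluoro compounds gives a number 5.5 percentage points higher from compound 2 to compound 4 (within the scatter), and the comparison with the high compound gives a number 49.8 percentage points lower from compound 1 to compound 4 (beyond the scatter), so among these four compounds only compound 1 stands apart, with its steps to all three others printed as beyond the scatter. This shows that, in this small set, the outcome of the change depends on where the methoxy sits, but it rests on just two instances read at one concentration, and it shows neither the cause of the difference nor how the change would behave on any further core.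

Only methoxy and fluoro appear on the aryl group here, which leaves open whether the value of compound 1, 71.1%, is specific to methoxy at that place. An ethoxy, an amine or a carboxylic acid in the same place, or an unsubstituted phenyl, would bear on that question.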